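The source may hold more compounds than are shown below. What is called first, only, known or untested is meant among the compounds shown, and "the series" means these compounds.

Measured compounds in an in vitro assay on IMR-32 cells for binding affinity to Neuronal acetylcholine receptor; alpha3/beta4 (Homo sapiens); on this read-out higher numbers stand for weaker inhibition and lower numbers for stronger inhibition:
compound 1, `CC(=O)c1ccc2c(c1)C1CNCC2C1`, gives 69 nM;
compound 2, `N#Cc1ccc2c(c1)C1CNCC2C1`, gives 122 nM;
compound 3, `Fc1ccc2c(c1)C1CNCC2C1`, gives 1190 nM.

Compound 3 stands highest of the three numbers in this assay, the weakest binder of the set: the step of a 17-fold higher number from compound 1 to compound 3 (1.24 log units; beyond the scatter) and the step of a 9.8-fold higher number from compound 2 to compound 3 (0.99 log units; beyond the scatter) both lie beyond the scatter, while a 1.8-fold higher number from compound 1 to compound 2 (0.25 log units; within the scatter) does not.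

Compound 4, `Fc1cc2c(cc1F)C1CNCC2C1`, is not yet measured. It differs from compound 3 by fluoro in place of hydrogen on an aromatic carbon; the fluoro already present in compound 3 stays in place. For the measured compounds named here, none of the measured steps has this shape: each of them exchanges one group for another at the same aromatic carbon, and no step replaces a hydrogen with fluoro anywhere. Going by the values given here, the data therefore carry no direct precedent for the change, and no step beyond the scatter is expected in this assay from compound 3 to compound 4, a 1.1-fold lower number from compound 3 to compound 4 (0.03 log units; within the scatter), with a wide range around it. For compound 4 the estimate in this assay is 1100 nM, between 400 nM and 3000 nM.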

Compound 4, inhibition constant: 1000 nM
Beside the measured number, compound 4's estimate is 1.1-fold (0.04 log units) above it; the range from low to high includes it.
By their numbers in this assay, from the lowest: compounds 1 and 2 (each within the scatter of the next); then compounds 4 and 3 (each within the scatter of the next).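

In this assay, fluoro in place of hydrogen on the aromatic carbon ortho to a fluoro group gives a 1.2-fold lower number from compound 3 to compound 4 (0.08 log units; within the scatter), so this change leaves no readable effect on top of the fluoro of compound 3. Unlike the earlier steps, which exchange one group for another at a single aromatic carbon, this one fills a second aromatic carbon, and that carbon takes fluoro without a shift beyond the scatter. No measurement bears on why the number holds here.

On these data alone, whether this carbon would also accept an amine, a methoxy group or a carboxylic acid remains open. Also open, as far as these compounds go, is whether the same fluoro would leave the number unchanged on the core of compound 1 or compound 2, where acetyl or cyano takes the place of the first fluoro.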